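This account rests on a few compounds, and the source may have more. Where it says the series, first, only, none or still open, it means among the compounds named here.

Measured so far, in a functional assay on K562 cells (Homo sapiens) for antiproliferative activity, read by MTT assay, with a stated time of 72 h; a higher number here means a weaker inhibitor, a lower number a stronger inhibitor:
Compound 1 `COc1cc(-n2ncnc2-c2cccc([N+](=O)[O-])c2)cc(OC)c1OC`: > 10000 nM, a limit of the assay rather than a number.
Compound 2 `COc1cc(-n2ncnc2-c2ccc(OC(C)C)cc2)cc(OC)c1OC`: 800 nM.
Compound 3 `COc1ccc(-n2ncnc2-c2cc(OC)c(OC)c(OC)c2)cc1`: 3600 nM.

Compound 2 has the lowest of the two numbers in this assay; compound 3 stands higher, beyond the scatter. Compound 1 gives only a limit.

Compound 4 `COc1cc(-n2ncnc2-c2ccc(C)cc2)cc(OC)c1OC` differs from compound 2 in one place: methyl in place of isopropoxy on an aromatic carbon. Within the data shown here, no measured pair of compounds shows this change, so its size in this assay is open. A step in the weaker direction, beyond the scatter, is the expectation, since the entering methyl is much smaller than the leaving isopropoxy. The expected step from compound 2 to compound 4 in this assay is a 3.1-fold higher number from compound 2 to compound 4 (0.49 log units; beyond the scatter). Compound 4 is estimated at 2500 nM in this assay, with a range from 800 nM to 8000 nM.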

Compound 4, half-maximal inhibitory concentration: > 10000 nM
Compound 4: a limit, no number; the forecaster's own chance of this, stated with the estimate: 10%; at least 4.0-fold (0.60 log units) between middle value and limit.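

In this assay, among these compounds, methyl in place of isopropoxy gives an at least 12-fold higher number from compound 2 to compound 4 (1.09 log units; beyond the scatter), the first step that can be read at this place, para to a large group. Compound 4 gives > 10000 nM, a limit and not a number. The step is therefore a lower bound, not a measured size: the limit of > 10000 nM in this assay, at which 2 of the 4 values shown sit.

From the compounds shown here alone, whether the oxygen or the chain length carries the difference stays open; ethoxy or a longer alkoxy chain at this place would separate the two. Going by these compounds, how an amine here would compare is also open.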